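Moving the methoxy group and adding a fluorine on the pendant ring

The source may hold more compounds than are shown below. What is called first, only, known or untested is meant among the compounds shown, and "the series" means these compounds.

Of the compounds shown here, two sharing one core have been tested. Compound 1 `CCC1=C(O)c2c(oc(-c3ccc(OC(F)(F)F)cc3)cc2=O)C(CC)(CC)C1=O` and compound 2 `CCC1=C(O)c2c(oc(-c3cccc(OC)c3)cc2=O)C(CC)(CC)C1=O` differ only in the aromatic ring hanging from the shared core. In a functional assay on KB cells (Homo sapiens) for antiproliferative activity, read by sulforhodamine B assay, with a stated time of 3 days (on this read-out higher numbers stand for an effect only at larger amounts of compound and lower numbers for an effect already at smaller amounts), compound 1 gives 36.5 uM. In this assay compound 2 gives 13.3 uM, the lower of the two numbers; compound 1 sits at a higher value, and this gap lies beyond the usual scatter of repeated measurements.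

Compound 3 `CCC1=C(O)c2c(oc(-c3ccc(OC)c(F)c3)cc2=O)C(CC)(CC)C1=O` has not been measured. It differs from compound 2 by one change on the pendant ring: 3-fluoro-4-methoxyphenyl in place of 3-methoxyphenyl on an aromatic carbon. The methoxy group is thus kept but placed elsewhere on the ring, and a fluorine is added.

Within the data shown here, no measured pair shows a step of this exact kind, so the expectation rests on the two values alone. A small step from compound 2 to compound 3 of a 1.4-fold higher number from compound 2 to compound 3 (0.13 log units; within the scatter) is expected, about the size of the ordinary scatter, in neither direction with confidence. The estimate for compound 3 in this assay is 18 uM, with a range from 7 uM to 45 uM.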

Compound 3, concentration for half-maximal effect: 26.7 uM
Beside the measured number, compound 3's estimate is 1.5-fold (0.17 log units) below it; the range from low to high includes it.
By their numbers in this assay, from the lowest: compounds 2, 3 and 1 (each within the scatter of the next, the first and the last beyond it).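

In this assay, replacing 3-methoxyphenyl with 3-fluoro-4-methoxyphenyl gives a 2.0-fold higher number from compound 2 to compound 3 (0.30 log units; within the scatter) and so leaves compound 2 and compound 3 indistinguishable on this read-out. Among these compounds, this is the first direct look at a single change on the pendant ring, which is attached next to the ring oxygen of the shared core: here the ring takes an extra fluorine and a relocated methoxy group without a difference that stands clear of ordinary measurement noise. No measurement available here explains this outcome, and with a step this small there is little to explain.

Because the methoxy group moves and the fluorine arrives in the same step, the compounds shown cannot say what each change does alone, or whether their separate effects are small or happen to cancel. Also open, going by these compounds, is how this pendant ring would read with a quite different group on it, such as an amine, a carboxylic acid or a longer alkyl chain, and whether any such group would produce a step beyond the scatter.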